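Shortening the tetradecyl chain of compound 1 by two carbons

The source may report more compounds than this note shows. Statements on the series, on what has been measured and on what is new or still open speak of the compounds shown alone.

Compound 1 `CCCCCCCCCCCCCCNc1nc(=O)c2ncn([C@@H]3O[C@H](CO)[C@@H](O)[C@H]3O)c2c(=O)[nH]1` carries the higher of the two numbers that were obtained in an assay on isolated protein for inhibition of ATP-dependent RNA helicase SUPV3L1, mitochondrial (Homo sapiens); a lower number here means a stronger inhibitor, a higher number a weaker inhibitor: compound 1 gives 300 ug/mL. Compound 2 `CCCCCCCCCCCCNc1nc(=O)c2c(ncn2[C@H]2C[C@H](O)[C@@H](CO)O2)c(=O)[nH]1`, which bears a dodecyl chain on a different sugar, gives 3 ug/mL in this assay. Compound 3 `CCCCCCCCCCNc1nc(=O)c2ncn([C@@H]3O[C@H](CO)[C@@H](O)[C@H]3O)c2c(=O)[nH]1` reaches only a limit of this assay, > 500 ug/mL, so for compound 3 no number is known. The step of an at least 1.6-fold higher number from compound 1 to compound 3 (0.22 log units; that floor lies within the scatter) therefore ends at the limit of > 500 ug/mL in this assay, at which 1 of the 3 values shown sits.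

Compound 4 `CCCCCCCCCCCCNc1nc(=O)c2ncn([C@@H]3O[C@H](CO)[C@@H](O)[C@H]3O)c2c(=O)[nH]1` differs from compound 1 by hydrogen in place of ethyl on a saturated chain carbon, ten or more bonds along the chain from a nitrogen on an aromatic ring. Among the measured compounds shown here, the only measured step that bears on this change is an at least 1.6-fold higher number from compound 1 to compound 3 (0.22 log units; that floor lies within the scatter), the removal of a larger piece at the same place, which went to the limit. For the measured compounds named here, compound 2 shares the dodecyl chain of compound 4 but not its sugar, and no single step connects the two; its value alone shows nothing about the chain. Going by the values given here, the change from compound 1 to compound 4 is smaller than the one to compound 3, so a step in the same direction, or none beyond the scatter, is expected. Compound 4 is therefore expected at 450 ug/mL, within 200 ug/mL to 1000 ug/mL. This expected step is a 1.5-fold higher number from compound 1 to compound 4 (0.18 log units; within the scatter), with a fair chance that compound 4 also returns only a limit.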

Compound 4, half-maximal inhibitory concentration: > 500 ug/mL
Compound 4: a limit, no number (the forecaster's own chance of this, stated with the estimate: 45%); middle value at least 1.1-fold (0.04 log units) away from the limit.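

In this assay, among the compounds shown here, the loss of ethyl alone gives an at least 1.6-fold higher number from compound 1 to compound 4 (0.22 log units; that floor lies within the scatter), so a smaller cut than the one leading to compound 3 is already enough to leave the measurable range, although the true size of the step may be small or large. Compound 4 returns > 500 ug/mL, which is a limit and not a number, and it joins compound 3 there: the limit of > 500 ug/mL in this assay, at which 2 of the 4 values shown sit. Of the three compounds on this sugar, only compound 1 therefore has a number, and the step between compound 3 and compound 4 cannot be read, as both are limits.

Compound 2, which has the dodecyl chain on a different sugar, gives 3 ug/mL, but the compounds shown do not establish how much of the gap to the compounds on this sugar belongs to the sugar itself. Going by these compounds, it also remains open whether a longer chain than tetradecyl, or an amine or a carboxylic acid on the chain, would lower the number on this sugar.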